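A few compounds are considered here, and "the series" means these few. Any claim that something is new, unique, unknown or untested is made for them only; others in the source may bear on it.

Measured so far:
compound 1, `O=C(Nc1ccccc1Br)N[C@@H]1CCN(c2cccc(F)c2)C1`, 7.8
compound 2, `O=C(Nc1ccccc1Br)N[C@@H]1CCN(c2cc(C(F)(F)F)ccn2)C1`, 6.9
compound 3, `O=C(NCCN1CCc2c(F)cccc21)Nc1ccccc1Br`, 7.4

In a functional assay for antagonist activity at transient receptor potential cation channel subfamily V member 1 (Rattus norvegicus), read by FLIPR (a higher number here means a more potent compound, by a factor of ten per unit of this negative logarithm, a lower number a less potent compound), compound 1 gives 7.8, the highest of the three numbers. Compound 3 stands nearest with 7.4, a gap beyond the scatter. Compound 2 lies furthest off with 6.9, also beyond the scatter. Compound 4 is `O=C(Nc1ccccc1Br)N[C@@H]1CCN(c2ccc(Br)cn2)C1` and has not yet been measured in this assay. It differs from compound 1 in one place: 5-bromopyridin-2-yl in place of 3-fluorophenyl on an amine nitrogen in a ring. Among the measured compounds shown here, no two measured compounds differ in just one place, so no measured step guides this change directly. For the measured compounds named here, the expectation rests on compound 2, the only measured compound whose amine nitrogen in a ring carries a six-membered aromatic ring with 1 hetero atom, and it gives 6.9, the lowest number. Compound 4 is expected to come in lower, with the step of a number 0.60 log units lower from compound 1 to compound 4 (beyond the scatter) beyond the scatter but smaller than the gap down to compound 2. Compound 4 is estimated at 7.2, with a range from 6.5 to 7.9.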

Compound 4, negative logarithm of the antagonist equilibrium constant: 7.2
Beside the measured number, compound 4's estimate shows no gap at the digits printed, within the range that was stated.
By their numbers in this assay, from the lowest: compounds 2, 4 and 3 (each within the scatter of the next, the first and the last beyond it); then compound 1.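

Among the compounds shown here, on the amine nitrogen in the ring, 5-bromopyridin-2-yl in place of 3-fluorophenyl gives the first single-change reading at this place in this assay: a number 0.60 log units lower from compound 1 to compound 4 (beyond the scatter). Compound 4 stands within the scatter of the other compound with a six-membered aromatic ring with 1 hetero atom here, compound 2 at 6.9, so these two pyridine-bearing compounds cannot be ordered. The change swaps the ring type and the halogen together, so the step cannot be divided between the ring nitrogen and the bromine.

A bromophenyl group or an unsubstituted pyridin-2-yl group on the same nitrogen would be needed to separate those two contributions. The compounds shown come with no measurement that accounts for the step.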